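Methoxy on the benzyl group of compound 3

A few compounds are considered here, and "the series" means these few. Any claim that something is new, unique, unknown or untested is made for them only; others in the source may bear on it.

Compound 1 `Cc1ccccc1Nc1nc(NCc2ccncc2)ncc1Cl` gives > 100000 nM
Compound 2 `Cc1ccccc1Nc1nc(Nc2ccc(N3CCCN(C)CC3)cc2)ncc1Cl` gives 6390 nM
Compound 3 `CN1CCN(c2ccc(Nc3ncc(Cl)c(NCc4ccccc4)n3)nc2)CC1` gives 24800 nM

All three were read in a functional assay on MDA-MB-231 cells (Homo sapiens) for inhibition, read by CCK-8 assay, with a stated time of 48 h (on this read-out higher numbers stand for weaker inhibition of growth and lower numbers for stronger inhibition of growth), and share one core. The entry for compound 1 at > 100000 nM is a limit of the assay, not a number. Going by the values given here, only two numbers remain, and compound 3 at 24800 nM has the higher one. Compound 2 at 6390 nM lies lower, beyond the usual scatter.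

Compound 4 `COc1ccc(CNc2nc(Nc3ccc(N4CCN(C)CC4)cn3)ncc2Cl)cc1` carries methoxy in place of hydrogen on an aromatic carbon, which turns benzyl into 4-methoxybenzyl. Among the compounds with values here, no measured pair shows this change, so the expectation is loose. In this assay no shift beyond the scatter is expected, in either direction. The estimated 1.2-fold lower number from compound 3 to compound 4 (0.09 log units; within the scatter) is therefore small. For compound 4 the estimated value is 20000 nM with an expected range from 8000 nM to 50000 nM in this read-out.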

Compound 4, concentration for 50% growth inhibition: 14900 nM
Beside the measured number, compound 4's estimate is 1.3-fold (0.13 log units) above it; the measured number falls inside the stated range.
By their numbers in this assay, from the lowest: compound 2; then compounds 4 and 3 (each within the scatter of the next). At a limit, above all of these: compound 1.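

In this assay the methoxy change on the benzyl group of compound 3 reads a 1.7-fold lower number from compound 3 to compound 4 (0.22 log units; within the scatter) and is the only step at this position among the compounds shown. Replacing benzyl with 4-methoxybenzyl, which adds one hydrogen-bond acceptor and no net charge on the six-membered aromatic ring, therefore leaves the number within the scatter, and this position accepts methoxy without a shift that can be told apart from repeat measurements. No measurement given here bears on why this change has so little effect.

A single group at a single place cannot show whether this ring position responds to other groups, such as a carboxylic acid, an amine or a longer alkoxy chain. On these data alone, it also remains open whether methoxy on another carbon of the same ring would stay within the scatter.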